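Swapping amino for chloro on a purine-type core

The source may report more compounds than this note shows. Statements on the series, on what has been measured and on what is new or still open speak of the compounds shown alone.

Measured compounds:
compound 1 `ClCc1ccc(Cn2cnc3c(Cl)ncnc32)cc1` gives 2300 nM
compound 2 `Nc1nc(Cl)c2ncn(Cc3ccccc3CCl)c2n1` gives "not determined" (no result reported)
compound 3 `ClCc1ccccc1Cn1cnc2ncnc(Cl)c21` gives 1650 nM

The assay here is a functional assay on RXF 393 cells (Homo sapiens) for cytotoxicity, read by sulforhodamine B assay, with a stated time of 48 h; a higher number here means a weaker inhibitor of growth, a lower number a stronger inhibitor of growth. Compound 1 `ClCc1ccc(Cn2cnc3c(Cl)ncnc32)cc1` gives 2300 nM in this assay, and compound 3 `ClCc1ccccc1Cn1cnc2ncnc(Cl)c21` gives 1650 nM; these two values lie within the usual scatter of each other, so nothing can be said about an order between them. Compound 2 `Nc1nc(Cl)c2ncn(Cc3ccccc3CCl)c2n1` stands apart: in this assay compound 2 is reported as "not determined" (no result reported), so it has no place among the values shown.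

Compound 4 `ClCc1ccccc1Cn1cnc2c(Cl)nc(Cl)nc21` has not yet been measured. It differs from compound 2 in one spot, described as chloro in place of amino on an aromatic carbon. Among the measured compounds shown here, because compound 2 is reported as "not determined" (no result reported) no step between measured compounds can be computed for this change, and nothing in the data shows how an amino group at this spot behaves against a chloro group. For the measured compounds named here, the only guide is compound 3, which shares the chloro at the neighbouring aromatic carbon and the same benzyl arm, and gives 1650 nM. On that basis compound 4 is expected to fall in the same region, with wider uncertainty than usual: an estimated 1800 nM, plausibly ranging from 600 nM to 5500 nM.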

Compound 4, concentration for 50% growth inhibition: 100 nM
Compound 4: middle estimate off by 18-fold (1.26 log units), on the high side; measured number below the stated range.
By their numbers in this assay, from the lowest: compound 4; then compounds 3 and 1 (each within the scatter of the next).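

No step can be read from compound 2 to compound 4: in this assay compound 2 stands as "not determined" (no result reported), and the swap of amino for chloro therefore has no measured size here. The compounds shown leave open how an amino group at this spot compares with a chloro group. Nothing measured here offers an explanation for the value of compound 4.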